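This account rests on a few compounds, and the source may have more. Where it says the series, first, only, none or still open, it means among the compounds named here.

Compound 3 `COc1ccc(-c2cnc(NC(=O)C3CCOCC3)n2C)cc1` was tested in a toxicity assay on THP-1 cells (Homo sapiens) for inhibition; on this read-out higher numbers stand for lower toxicity in this test and lower numbers for higher toxicity in this test. In this assay compound 3 is reported only as the limit of > 100000 nM. Compound 1 `COc1ccc(-c2cnc(NC(=O)c3ccccn3)n2C)cc1` likewise gives only the limit of > 100000 nM in this assay. Compound 2 `COc1ccc(-c2cnc(NC(=O)c3ccco3)n2C)cc1` also stands at the limit of > 100000 nM in this assay. The measured steps a step that the two limits leave unreadable from compound 1 to compound 2, a step that the two limits leave unreadable from compound 1 to compound 3 and a step that the two limits leave unreadable from compound 2 to compound 3 therefore carry no readable size, because of the limit of > 100000 nM in this assay, at which 3 of the 3 values shown sit. Compound 4 `COc1ccc(-c2cnc(NC(=O)c3cccc(Br)c3)n2C)cc1` has not yet been measured; it differs from compound 3 by 3-bromophenyl in place of oxan-4-yl on a carbonyl carbon. Among the measured compounds shown here, none of the measured steps gives a readable size or direction for this change. The step of a number no higher from compound 3 to compound 4 (the limit leaves the size open) is therefore expected to stay within the scatter. For compound 4 the estimate in this assay is 100000 nM, with a range from 30000 nM to 300000 nM, and most likely once more only a limit is reported.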

Compound 4, half-maximal cytotoxic concentration: > 100000 nM
Compound 4 gave a limit, no number (the forecaster's own chance of this, stated with the estimate: 70%); the middle value sits exactly at the limit.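

In this assay compound 4 yields no readable step against compound 1, compound 2 or compound 3, because all of them give only a limit: the limit of > 100000 nM in this assay, at which 4 of the 4 values shown sit. The compounds shown leave open whether any group on the carbonyl carbon would give a measurable toxicity value.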